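This account rests on a few compounds, and the source may have more. Where it says the series, first, only, none or still open, it means among the compounds named here.

Measured in an ADME assay on HEK293 cells (Homo sapiens) for cytotoxicity, with a stated time of 72 h; a lower number here means that less compound is needed, a higher number that more compound is needed for the effect:
Compound 1 `CSc1ccccc1NC(=O)Nc1cc(C)nc2ccccc12`: > 25000 nM
Compound 2 `COc1ccccc1NC(=O)Nc1cc(C)nc2ccccc12`: > 25000 nM

Both entries are limits of the assay and not numbers. Compound 2 stands at > 25000 nM, which is a limit. The evidence so far comes to one observation: the limit of > 25000 nM in this assay, at which 2 of the 2 values shown sit.

The next molecule, compound 3 `Cc1cc(NC(=O)Nc2ccccc2C(F)(F)F)c2ccccc2n1`, carries trifluoromethyl in place of methoxy on an aromatic carbon, ortho to a large group (trifluoromethyl in place of methoxy on an aromatic carbon).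

Among the compounds with values here, only one measured step can guide expectations here, a step that the two limits leave unreadable from compound 1 to compound 2. It also changes a group on an aromatic carbon, but it has no readable size, so it offers no measure of how far such a swap can move this assay. No step beyond the scatter is therefore expected, and another limit is the likeliest result. The estimate corresponds to a number no higher from compound 2 to compound 3 (the limit leaves the size open).

Compound 3 is expected at about 25000 nM, with an estimated range of 10000 nM to 50000 nM.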

Compound 3, half-maximal effective concentration in the HEK293 assay: > 25000 nM
Compound 3 gave a limit, no number (the forecaster's own chance of this, stated with the estimate: 80%); the middle value sits exactly at the limit.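

In the HEK293 assay compound 3 gives > 25000 nM as a limit and not a number. Within the data shown here, compound 1 and compound 2 also give limits and not numbers, so no step between these compounds can be read. In a physicochemical assay for solubility, at pH 7.4 (a higher number here means a more soluble compound, a lower number a less soluble compound), compound 2 gives 100 nM and compound 3 gives 3800 nM as measured values. In the physicochemical assay trifluoromethyl in place of methoxy on an aromatic carbon gives a 38-fold higher number from compound 2 to compound 3 (1.58 log units; beyond the scatter) here. In the HEK293 assay the compounds shown leave open what concentration of any of them produces the effect, since all three stop at the same limit: the limit of > 25000 nM in the HEK293 assay, at which 3 of the 3 values shown sit.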